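The compounds below may be only part of what the source reports. "The series", "measured", "known", "first", "only" and "open" are said of these compounds alone.

Measured in a functional assay on RAW264.7 cells (Mus musculus) for inhibition, read by Griess assay, with stated times of 2 h and 18 h; on this read-out lower numbers stand for stronger inhibition and higher numbers for weaker inhibition:

- Compound 1 `C[C@@H]1C(=O)C(O)=C2C(C)(C)C(=O)CC[C@]2(C)[C@@]1(O)CCc1ccoc1`: > 50000 nM
- Compound 2 `CC1=C(CCc2ccoc2)[C@@]2(C)CCCC(C)(C)C2=C(O)C1=O`: 46100 nM
- Compound 3 `CCOC1CC(O)(CCC2=C(C)C(=O)C(O)=C3C(C)(C)C(=O)CC[C@]23C)CO1`: 22900 nM

Compound 1 gives > 50000 nM, which is a limit of the assay and not a number.

Compound 2 at 46100 nM and compound 3 at 22900 nM lie within the usual scatter of each other, so this assay does not separate them. Compound 3 therefore stands level with compound 2 among the two true numbers.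

The next molecule is compound 4 `CO[C@@H]1C=C(CCC2=C(C)C(=O)C(O)=C3C(C)(C)C(=O)CC[C@]23C)C(=O)O1`. It keeps the rest of compound 3 but replaces the 5-ethoxy-3-hydroxyoxolan-3-yl group, on a saturated chain carbon, two bonds along the chain from a double-bonded ring carbon: a group of 8 heavy atoms (5 carbon, 3 oxygen; one five-membered non-aromatic ring with 1 hetero atom) in place of a group of 9 heavy atoms (6 carbon, 3 oxygen; one five-membered non-aromatic ring with 1 hetero atom), on a saturated chain carbon, two bonds along the chain from a double-bonded ring carbon. The new group has no common name and also holds a five-membered non-aromatic ring.

Among the measured compounds shown here, no measured pair differs in one place, so the expectation is only a rough one. The estimated step of a 1.5-fold lower number from compound 3 to compound 4 (0.18 log units; within the scatter) is small, leans towards a lower number and may stay within the scatter.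

For compound 4 the estimated value is 15000 nM, with an expected range of 5000 nM to 40000 nM.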

Compound 4, half-maximal inhibitory concentration: > 50000 nM
Compound 4: a limit, no number; the forecaster's own chance of this, stated with the estimate: 15%; at least 3.3-fold (0.52 log units) between middle value and limit.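

Replacing the 5-ethoxy-3-hydroxyoxolan-3-yl group gives an at least 2.1-fold higher number from compound 3 to compound 4 (0.33 log units; beyond the scatter) in this assay, so this saturated chain carbon does not treat all five-membered non-aromatic ring groups alike. The entering group goes from 1 hydrogen-bond donor to 0 and brings 2 double bonds outside aromatic rings, but a single change cannot show which of these differences matters. Compound 4 stands at a limit and not a number, so the full size of the step cannot be read: the limit of > 50000 nM in this assay, at which 2 of the 4 values shown sit.

The compounds shown leave open which feature of the new group goes with the higher number. They also leave open whether an amine or a carboxylic acid on this saturated chain carbon would give a lower number than compound 3 in this assay.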